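This account rests on a few compounds, and the source may have more. Where it says the series, first, only, none or still open, it means among the compounds named here.

Of the compounds shown here, three sharing one core have been tested in a functional assay on AN3-CA cells (Homo sapiens) for antiproliferative activity, read by MTT assay, with a stated time of 72 h; a higher number here means a weaker inhibitor, a lower number a stronger inhibitor. Compound 1 `O=C(Nc1ccc(Cl)c(-c2nnc3c(Cl)cccn23)c1)c1ccc(C(F)(F)F)cc1F` gives 41200 nM in this assay. Compound 2 `O=C(Nc1ccc(Cl)c(-c2nnc3c(Cl)cccn23)c1)c1cccc(Cl)c1` gives 68400 nM in this assay. Compound 3 `O=C(Nc1ccc(Cl)c(-c2nnc3c(Cl)cccn23)c1)c1c(F)cccc1Cl` reaches only the limit of this assay, > 100000 nM, so no number is known for it. The step of an at least 1.4-fold higher number from compound 2 to compound 3 (0.16 log units; that floor lies within the scatter) accordingly rests on that limit (the limit of > 100000 nM in this assay, at which 1 of the 3 values shown sits), and its floor lies within the scatter. Compound 4 `O=C(Nc1ccc(Cl)c(-c2nnc3c(Cl)cccn23)c1)c1ccccn1` differs from compound 3 by pyridin-2-yl in place of 2-chloro-6-fluorophenyl on a carbonyl carbon. Among the compounds with values here, no measured step exchanges the group on the carbonyl carbon for pyridin-2-yl, so only the weak level of the three values and the step of an at least 1.4-fold higher number from compound 2 to compound 3 (0.16 log units; that floor lies within the scatter) bear on it, and that single exchange at the carbonyl carbon moved the number at most modestly. Compound 4 is therefore expected to remain a weak inhibitor, with the step of an at least 1.4-fold lower number from compound 3 to compound 4 (0.15 log units; that floor lies within the scatter) expected to stay small. Compound 4 is estimated at 70000 nM, within 25000 nM to 200000 nM, with a real chance that this assay again reports only its limit.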

Compound 4, half-maximal inhibitory concentration: > 100000 nM
Compound 4 gave a limit, no number; the forecaster's own chance of this, stated with the estimate: 45%; middle value at least 1.4-fold (0.15 log units) away from the limit.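

Within the data shown here, with pyridin-2-yl on the carbonyl carbon, a ring with a hetero atom now stands where the earlier compounds carried only halogenated phenyl rings, and in this assay compound 4 gives only a limit, > 100000 nM. The comparison with the 3-chlorophenyl group is an at least 1.4-fold higher number from compound 2 to compound 4 (0.16 log units; that floor lies within the scatter), while the step between the two limits cannot be read. The exchange therefore brings no readable gain at this position, and what can be learned here is now restricted: the limit of > 100000 nM in this assay, at which 2 of the 4 values shown sit.

Going by these compounds, how far compound 3 and compound 4 lie beyond that limit stays open, and so does whether they differ at all. Also open, on these data alone, is whether an aliphatic amine or a carboxylic acid on the carbonyl-bound ring would give a readable number.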